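The compounds below may be only part of what the source reports. "The series", "measured", "known", "first", "only" and "open" are said of these compounds alone.

This piece follows a single change made to compound 1, whose structure is `COc1cc(-c2nn(-c3cccc(NC(=O)c4cccc(C(F)(F)F)c4)c3)cc2-c2ccncc2)ccc1Cl`. In a functional assay on UO-31 cells (Homo sapiens) for inhibition, read by sulforhodamine B assay, with a stated time of 48 h (on this read-out higher numbers stand for lower toxicity in this test and lower numbers for higher toxicity in this test), compound 1 reaches only the limit of the test, giving > 50000 nM, so no number is known for it. A second compound, compound 2, with the structure `O=C(Nc1cccc(-n2cc(-c3ccncc3)c(-c3ccc(Cl)c(O)c3)n2)c1)Nc1cc(C(F)(F)F)cc(C(F)(F)F)c1`, was measured in the same test. In this assay compound 2 gives 6600 nM. Going by the values given here, no step between two measured compounds is available here; the only fixed point for compound 1 is the limit at the limit of > 50000 nM in this assay, at which 1 of the 2 values shown sits. The new compound, compound 3, has the structure `COc1cc(-c2nn(-c3cccc(NC(=O)Nc4ccc(Cl)c(Cl)c4)c3)cc2-c2ccncc2)ccc1Cl` and is yet to be measured in this assay. Its difference from compound 1 is (3,4-dichlorophenyl)amino in place of 3-(trifluoromethyl)phenyl on a carbonyl carbon. Because compound 1 sits at the limit (the limit of > 50000 nM in this assay, at which 1 of the 2 values shown sits), the direction of the step cannot be read from a number. On the evidence of compound 2, which gave 6600 nM, a step toward higher toxicity, beyond the scatter, is the expectation. Compound 3 is therefore estimated at 20000 nM in this assay, within 5000 nM to 50000 nM. The step this estimate implies is an at least 2.5-fold lower number from compound 1 to compound 3 (0.39 log units; beyond the scatter), an expectation rather than a measurement.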

Compound 3, concentration lethal to 50% of the cells: > 50000 nM
Compound 3 gave a limit, no number; the forecaster's own chance of this, stated with the estimate: 40%; middle value at least 2.5-fold (0.39 log units) from the limit.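

In this assay, going by these compounds alone, compound 1 and compound 3 both stop at a limit rather than giving a number, so no step between them can be read: the limit of > 50000 nM in this assay, at which 2 of the 3 values shown sit.

From the compounds shown here alone, whether (3,4-dichlorophenyl)amino in place of 3-(trifluoromethyl)phenyl on a carbonyl carbon changes the read-out at all stays open, as do the direction and size of any such change.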